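Cytotoxicity of a Benzamide Series: Biphenyl Gives Way to Isobutoxy

The source may hold more compounds than are shown below. What is called first, only, known or untested is meant among the compounds shown, and "the series" means these compounds.

Compound 1, `CC(C)N(Cc1cccc(OCCCCCC(=O)O)c1)C(=O)c1ccccc1`, in an ADME assay on HEK293 cells (Homo sapiens) for cytotoxicity, read by CellTiter-Glo and resazurin assay, with a stated time of 72 h (a higher number here means that more compound is needed for the effect, a lower number that less compound is needed), gives > 26000 nM, a limit of the assay.
Compound 2, `CC(C)N(Cc1cccc(OCCCCCC(=O)O)c1)C(=O)c1ccc(-c2cccc3ccccc23)cc1`, in this assay gives > 26000 nM, a limit of the assay.
Compound 3, `CC(C)N(Cc1cccc(OCCCCCC(=O)O)c1)C(=O)c1ccc(-c2cccc(-c3ccccc3)c2)cc1`, in this assay gives > 26000 nM, a limit of the assay.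

Compound 3 stands at a limit in this assay, and no number is known for it. The other two compounds show the same picture, so that (the limit of > 26000 nM in this assay, at which 3 of the 3 values shown sit); no order among the three can be read from these values.

Compound 4, `CC(C)COc1cccc(-c2ccc(C(=O)N(Cc3cccc(OCCCCCC(=O)O)c3)C(C)C)cc2)c1`, differs from compound 3 by isobutoxy in place of phenyl on an aromatic carbon. Two measured steps end at compound 3 and therefore bear on this change: a step that the two limits leave unreadable from compound 1 to compound 3 and a step that the two limits leave unreadable from compound 2 to compound 3. Both are unreadable, because each end is a limit, so they give no size and no direction. The three compounds share the core, the acid-bearing chain and the amide, and none of them has reached a readable value in this assay. The expectation for the step is therefore no step beyond the scatter, expressed as a number no higher from compound 3 to compound 4 (the limit leaves the size open), and most likely again only a limit. Compound 4 is accordingly estimated at 26000 nM, with a range from 13000 nM to 52000 nM.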

Compound 4, half-maximal effective concentration: > 26000 nM
Compound 4: only a limit was reported (the forecaster's own chance of this, stated with the estimate: 80%); the middle value lies on the limit itself.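

Compound 4 also stands at a limit, so its steps from compound 1, compound 2 and compound 3 cannot be read in size or direction: the limit of > 26000 nM in this assay, at which 4 of the 4 values shown sit. The compounds shown leave open at what concentration any of the four would reach its half-maximal effect in this assay.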